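The source may hold more compounds than are shown below. What is called first, only, known or untested is meant among the compounds shown, and "the series" means these compounds.

Measured so far:
compound 1 `CC(/N=c1\c(O)c(O)\c1=N/Cc1ccc(C#N)cc1Cl)C(C)(C)C` — 180 nM
compound 2 `CCC(C)(C)/N=c1\c(O)c(O)\c1=N/Cc1c(C)cc(C)cc1C` — 310 nM
compound 3 `Cc1cc(C#N)cc(Cl)c1C/N=c1\c(O)c(O)\c1=N/C(C)C(C)(C)C` — 1900 nM

All three numbers come from a functional assay for inhibition, with Rattus norvegicus as the target; a higher number here means a weaker inhibitor, a lower number a stronger inhibitor. Compound 3 and compound 1 differ in one place, (hydrogen in place of methyl on an aromatic carbon), and that change gave an 11-fold lower number from compound 3 to compound 1 (1.02 log units; beyond the scatter). Compound 2 sits between the other two: its gap to compound 1 is within the scatter, its gap to compound 3 beyond it. Going by the values given here, no single-place step is counted between compound 2 and compound 3; the difference between the two cores is not broken down here.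

Compound 4 `CCC(C)(C)/N=c1\c(O)c(O)\c1=N/Cc1ccc(C)cc1C` is not yet measured. It differs from compound 2 by hydrogen in place of methyl on an aromatic carbon. Among the compounds with values here, this is the same kind of change as the one from compound 3 to compound 1, not the same: in both the place is ortho to a large group, but in compound 3 it is meta to a chloro group and meta to a cyano group, whereas in compound 2 it is meta to two methyl groups. The change has been measured once only, in different surroundings, so the expectation carries wide bounds. In this assay the expected step is a 2.6-fold lower number from compound 2 to compound 4 (0.41 log units; beyond the scatter), smaller than an 11-fold lower number from compound 3 to compound 1 (1.02 log units; beyond the scatter), the starting point being that compound 2 gives 310 nM. Compound 4 is estimated at 120 nM, with a range from 40 nM to 400 nM.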

Compound 4, half-maximal inhibitory concentration: 530 nM
Beside the measured number, compound 4's estimate is 4.4-fold (0.65 log units) below it; measured number outside the range, above it.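

In this assay, hydrogen in place of methyl on an aromatic carbon gives a 1.7-fold higher number from compound 2 to compound 4 (0.23 log units; within the scatter), so this step on the core of compound 2 cannot be told from no change at all. The same change therefore does not carry over in size from one core to the other in this series, and the result on the core of compound 3 cannot serve as a general rule for this methyl group: the same change on two cores in this assay, an 11-fold lower number (1.02 log units; beyond the scatter) from compound 3 to compound 1 and a 1.7-fold higher number (0.23 log units; within the scatter) from compound 2 to compound 4, 18-fold (1.26 log units) apart, beyond the scatter of two such steps This does not show which difference between the two cores accounts for the gap, since they differ in more than one place, including two methyl groups on the ring of compound 2 against a chloro group and a cyano group on the ring of compound 3, and with a single step on each core it also gives no cause and no trend.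

Still open, on these data alone, is whether a core carrying only the chloro group or only the cyano group would follow the step from compound 3 to compound 1 or the step from compound 2 to compound 4. Also open, as far as these compounds go, is how a fluoro group or a methoxy group in place of this methyl would compare with hydrogen on either core.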